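Series notes: trifluoromethoxy replacing trifluoromethyl on the biphenyl terminus

A few compounds are considered here, and "the series" means these few. Any claim that something is new, unique, unknown or untested is made for them only; others in the source may bear on it.

Two members of the series have numbers in an assay on isolated protein for inhibition of 2-Hydroxyacid oxidase 2 (Rattus norvegicus); on this read-out higher numbers stand for weaker inhibition and lower numbers for stronger inhibition. Compound 1 `Cc1n[nH]c(C(=O)O)c1Cc1ccc(-c2ccc(F)cc2)cc1` gives 400 nM in this assay. Within the data shown here, compound 2 `Cc1n[nH]c(C(=O)O)c1Cc1ccc(-c2ccc(C(F)(F)F)cc2)cc1` gives 1100 nM in this assay, the higher of the two numbers; the one step recorded, a 2.8-fold higher number from compound 1 to compound 2 (0.44 log units; beyond the scatter), is beyond the scatter. Compound 3 `Cc1n[nH]c(C(=O)O)c1Cc1ccc(-c2ccc(OC(F)(F)F)cc2)cc1` has not yet been measured. It differs from compound 2 in one place: trifluoromethoxy in place of trifluoromethyl on an aromatic carbon. Among the measured compounds shown here, no measured step covers this exact exchange; the only step that bears on the same position is a 2.8-fold higher number from compound 1 to compound 2 (0.44 log units; beyond the scatter), where a larger fluorinated group in place of a smaller one moved the number upward by a modest amount. Trifluoromethoxy is again a larger group than the one it replaces, so a small upward step or no step beyond the scatter is expected for compound 3 in this assay, with an estimated change of a 1.4-fold higher number from compound 2 to compound 3 (0.13 log units; within the scatter). The number for compound 3 in this assay is expected to be about 1500 nM, between 600 nM and 4000 nM.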

Compound 3, half-maximal inhibitory concentration: 2000 nM
For compound 3 the middle estimate is 1.3-fold (0.12 log units) below the measured one, and the stated range covers the measured number.
By their numbers in this assay, from the lowest: compound 1; then compounds 2 and 3 (each within the scatter of the next).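

In this assay, trifluoromethoxy in place of trifluoromethyl on the aromatic carbon para to a large group gives a 1.8-fold higher number from compound 2 to compound 3 (0.26 log units; within the scatter), so the two groups cannot be told apart at this position, despite the oxygen and the hydrogen-bond acceptor counted for the entering group. Set against fluoro, the same group gives a 5.0-fold higher number from compound 1 to compound 3 (0.70 log units; beyond the scatter), which joins a 2.8-fold higher number from compound 1 to compound 2 (0.44 log units; beyond the scatter) as a second step beyond the scatter in the same direction: among the three compounds, fluoro stands apart from both larger fluorinated groups, while those two form one level. No measured evidence bears on the origin of these steps.

All three groups at this position carry fluorine, so the compounds shown leave open whether the separation from fluoro extends to groups without it, such as a methoxy, a nitrile or an amine. They also leave open how a chlorine or a simple hydrogen at the same carbon would read in this assay, and whether any such exchange would give a lower number than the one for fluoro.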